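Working notes: bromo in place of hydroxy

The source may report more compounds than this note shows. Statements on the series, on what has been measured and on what is new or still open speak of the compounds shown alone.

Measured in a functional assay on A549 cells (Homo sapiens) for inhibition, read by MTT assay, with a stated time of 24 h; on this read-out lower numbers stand for stronger inhibition and higher numbers for weaker inhibition:
- compound 1 `CC1(C)[C@H]2CC[C@]1(C)N(Cc1cn(-c3ccccc3Br)nn1)C(=O)C2`: 130 nM
- compound 2 `CC1(C)[C@H]2CC[C@]1(C)N(Cc1cn(-c3ccc(O)cc3)nn1)C(=O)C2`: 140 nM
- compound 3 `CC1(C)[C@H]2CC[C@]1(C)N(Cc1cn(-c3ccc(Br)cc3)nn1)C(=O)C2`: not yet measured

Compound 2, at 140 nM, lies within the scatter of compound 1, at 130 nM, so the two numbers give no order. The next step leads to compound 3, which keeps the shared core and changes one group: bromo in place of hydroxy on an aromatic carbon. This is bromo in place of hydroxy on an aromatic carbon, para to a large group, so 4-hydroxyphenyl becomes 4-bromophenyl.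

Within the data shown here, only one measured step bears on this change. In this assay, the exchange of 2-bromophenyl for 4-hydroxyphenyl gave a 1.1-fold higher number from compound 1 to compound 2 (0.03 log units; within the scatter). Among the measured compounds shown here, that step differs from the coming one in both group and place, so it is indirect evidence, and no measured pair shows this exact exchange. With so little data, no direction can be argued, and no step beyond the scatter is expected. The estimate is no change at the digits printed from compound 2 to compound 3 (within the scatter). For compound 3 the expected value is 140 nM, with an estimated range of 60 nM to 320 nM.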

Compound 3, half-maximal inhibitory concentration: 80 nM
Compound 3: the middle estimate sits 1.8-fold (0.24 log units) above what was measured; low and high end bracket the measured number.
By their numbers in this assay, from the lowest: compounds 3, 1 and 2 (each within the scatter of the next).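

In this assay, among these compounds, the only direct exchange at this position reads a 1.8-fold lower number from compound 2 to compound 3 (0.24 log units; within the scatter), so bromo and hydroxy on an aromatic carbon, para to a large group, cannot be told apart here, even though the exchange removes the hydrogen-bond donor and acceptor of hydroxy. The pair that differs only in where the bromo group sits on the phenyl reads a 1.6-fold lower number from compound 1 to compound 3 (0.21 log units; within the scatter), so 4-bromophenyl and 2-bromophenyl cannot be told apart either, and neither the group nor its place gives a readable difference across these three compounds. No evidence is available that bears on these steps.

The compounds shown carry only bromo and hydroxy on the phenyl, and all their numbers lie within the scatter of one another, so it remains open whether any substituent on this ring can move the number beyond the scatter. An amine or a carboxylic acid at the same place, or a longer chain such as butoxy, would show whether this position tolerates groups well beyond these two or whether the flat picture holds only for them.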